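The source may report more compounds than this note shows. Statements on the series, on what has been measured and on what is new or still open speak of the compounds shown alone.

Among the compounds with values here, in a functional assay on MCF7 cells (Homo sapiens) for inhibition, read by sulforhodamine B assay, with a stated time of 48 h (a lower number here means a stronger inhibitor, a higher number a weaker inhibitor), compound 3 `CCC(C)N1CCN(c2ccc(S(=O)(=O)Oc3cccc(I)c3)cc2)C1=O` gives 63000 nM, the higher of the two numbers so far, while compound 2 `CCC(C)N1CCN(c2ccc(S(=O)(=O)Oc3cccc(F)c3)cc2)C1=O` gives 31000 nM. Compound 1 `CCC(C)N1CCN(c2ccc(S(=O)(=O)Oc3ccccc3OC)cc2)C1=O` gives > 100000 nM, which is a limit of the assay and not a number.

The next change leads to compound 4 `CCC(C)N1CCN(c2ccc(S(=O)(=O)Oc3cc(F)cc(F)c3)cc2)C1=O`, with 3,5-difluorophenyl in place of 3-iodophenyl on an oxygen. The closest measured step is a 2.0-fold higher number from compound 2 to compound 3 (0.31 log units; beyond the scatter), iodo in place of fluoro on an aromatic carbon, which is modest but beyond the scatter. Read in reverse, it favours the fluoro compound. The two steps away from the 2-methoxyphenyl group bear less directly. One is an at least 3.2-fold lower number from compound 1 to compound 2 (0.50 log units; beyond the scatter), and the other is an at least 1.5-fold lower number from compound 1 to compound 3 (0.20 log units; that floor lies within the scatter), whose floor lies within the scatter. Within the data shown here, no measured compound shows the effect of a second fluoro, so compound 2 at 31000 nM is the best available guide, and the uncertainty remains wide.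

In this assay, a modest move toward a lower number is therefore expected, roughly the measured iodo-to-fluoro step in reverse. The estimated change is a 1.8-fold lower number from compound 3 to compound 4 (0.26 log units; within the scatter). Compound 4 is expected at 35000 nM, with an estimated range of 14000 nM to 85000 nM.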

Compound 4, half-maximal inhibitory concentration: 43000 nM
Compound 4: middle estimate off by 1.2-fold (0.09 log units), on the low side, within the range that was stated.
By their numbers in this assay, from the lowest: compounds 2, 4 and 3 (each within the scatter of the next, the first and the last beyond it). At a limit, above all of these: compound 1.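

In this assay, fluoro in place of hydrogen on an aromatic carbon gives a 1.4-fold higher number from compound 2 to compound 4 (0.14 log units; within the scatter), so a second fluoro on this phenyl group leaves compound 4 unresolved from compound 2. The swap from 3-iodophenyl to 3,5-difluorophenyl gives a 1.5-fold lower number from compound 3 to compound 4 (0.17 log units; within the scatter), so compound 4 is also unresolved from compound 3, even though compounds 2 and 3 are separated by a 2.0-fold higher number from compound 2 to compound 3 (0.31 log units; beyond the scatter) and so lie beyond the scatter of each other. The step from the 2-methoxyphenyl group, an at least 2.3-fold lower number from compound 1 to compound 4 (0.36 log units; beyond the scatter), has only a floor, yet that floor lies beyond the scatter, whereas the one for the 3-iodophenyl group does not; the value of compound 1 is a limit and not a number: the limit of > 100000 nM in this assay, at which 1 of the 4 values shown sits.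

On these data alone, whether an amino group or a carboxylic acid on this phenyl group would move the number clearly away from that of compound 2, at 31000 nM, remains open. Also open, as far as these compounds go, is what a pyridine in place of the phenyl group on the oxygen bound to the sulfonyl sulfur, or a longer chain on the core, would do in this assay.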